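3,4-Difluorophenyl in place of phenyl in compound 3

The source may hold more compounds than are shown below. What is called first, only, known or untested is meant among the compounds shown, and "the series" means these compounds.

Values measured in a functional assay on HeLa cells (Homo sapiens) for inhibition, read by MTT assay, with a stated time of 72 h (a lower number here means a stronger inhibitor, a higher number a weaker inhibitor), are as follows.
Compound 1 `COc1cccc(/C=C/C(=O)Nc2cc(OC)c(OC)c(OC)c2)c1` gives 16500 nM
Compound 2 `COc1cc(NC(=O)/C=C/c2cccc(OCc3ccccc3)c2)cc(OC)c1OC` gives 2200 nM
Compound 3 `C=C(Br)C(=O)Nc1cccc(/C=C/C(=O)Nc2ccccc2)c1` gives 7300 nM

Compound 3 stands in the middle of these numbers, with a higher number than compound 2 and a lower one than compound 1. Compound 4 `C=C(Br)C(=O)Nc1cccc(/C=C/C(=O)Nc2ccc(F)c(F)c2)c1` has not yet been measured. It carries 3,4-difluorophenyl in place of phenyl on an amide-type nitrogen. For the measured compounds named here, only one measured step bears on this, and only loosely: a 7.5-fold lower number from compound 1 to compound 2 (0.88 log units; beyond the scatter), modest but beyond the scatter, where phenyl replaces hydrogen on a saturated chain carbon bound to an oxygen on an aromatic ring. Going by the values given here, that step lies at a different place on a different core, and no measured step shows the present change. Only a small move toward a lower number in this assay is therefore expected, perhaps barely beyond the scatter. The expected change is a 1.5-fold lower number from compound 3 to compound 4 (0.16 log units; within the scatter) in this estimate. For compound 4 the estimated value is 5000 nM, with an expected range from 1800 nM to 14000 nM.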

Compound 4, half-maximal inhibitory concentration: 1900 nM
For compound 4 the middle estimate is 2.6-fold (0.42 log units) above the measured one, and the stated range covers the measured number.
By their numbers in this assay, from the lowest: compounds 4 and 2 (each within the scatter of the next); then compound 3; then compound 1.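

In this assay, the replacement of phenyl by 3,4-difluorophenyl on the amide-type nitrogen gives a 3.8-fold lower number from compound 3 to compound 4 (0.58 log units; beyond the scatter). For the compounds shown here, this is the first measured step at this position, and it shows that the group on that nitrogen can shift the number beyond the scatter; the only earlier step concerned a different place on a different core. Nothing shown accounts for the size or direction of this change.

The compounds shown leave open whether the step needs both fluorines or whether a single fluorine on the phenyl would give the same number. They also leave open how chlorine, a nitrile or an amine on this ring would compare, and whether the same replacement would have a similar effect on another core.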